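Removing a Fluorine From a Weakly Cytotoxic Thioether

The compounds below may be only part of what the source reports. "The series", "measured", "known", "first", "only" and "open" are said of these compounds alone.

Measured compounds:
compound 1, `CC(O)(CSc1ccc(F)cc1)c1nc(-c2ccc(Cl)cc2)no1`: 36300 nM
compound 2, `CC(O)(CS(=O)(=O)c1ccc(Br)cc1)c1nc(-c2ccccc2)no1`: > 100000 nM
compound 3, `CC(O)(CS(=O)(=O)c1ccc(Br)cc1)c1nc(-c2ccc(Cl)cc2)no1`: > 100000 nM

The read-out throughout is a functional assay on DU-145 cells (Homo sapiens) for cytotoxicity, read by MTT assay; on this read-out higher numbers stand for weaker inhibition and lower numbers for stronger inhibition. For the measured compounds named here, compound 1 is the only compound with an actual number: in this assay compound 1 gives 36300 nM. The two other values sit at the limit of > 100000 nM in this assay, at which 2 of the 3 values shown sit. For compound 2 the value > 100000 nM is a limit of the assay, not a number. For compound 3 the value > 100000 nM is likewise a limit. The step that the two limits leave unreadable from compound 2 to compound 3 therefore cannot be read.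

Compound 4, `CC(O)(CSc1ccccc1)c1nc(-c2ccc(Cl)cc2)no1`, differs from compound 1 by hydrogen in place of fluoro on an aromatic carbon. Going by the values given here, no measured step bears on this change: compounds 2 and 3 differ from compound 1 in more than one place, and their limits give no size. What remains is a small change at a single position. The step of a 1.1-fold higher number from compound 1 to compound 4 (0.04 log units; within the scatter) is expected to stay within the usual scatter, in no definite direction. Compound 4 is accordingly estimated at 40000 nM, with a range from 15000 nM to 100000 nM.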

Compound 4, half-maximal inhibitory concentration: 4500 nM
The estimate for compound 4 lay 8.9-fold (0.95 log units) above the measured number; measured number outside the range, below it.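

In this assay, hydrogen in place of fluoro on the aromatic ring gives an 8.1-fold lower number from compound 1 to compound 4 (0.91 log units; beyond the scatter), so this single position, para to a large group, clearly counts for cytotoxicity, and the fluoro is not a neutral passenger here. Compounds 2 and 3 could not show this: both differ from compound 1 in more than one place, and both values are limits of the assay, so no size could be read from them. Nothing shown here explains why this change has so large an effect.

On these data alone, it remains open whether hydrogen is the best choice at this position, or whether a methoxy group or an amine there would strengthen or weaken inhibition further. A single pair also leaves open whether the same change would have a similar effect on a different core.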